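Removing a methyl from compound 3: cytotoxicity outlook

A few compounds are considered here, and "the series" means these few. Any claim that something is new, unique, unknown or untested is made for them only; others in the source may bear on it.

Three compounds have been measured in an ADME assay on MT4 cells (Homo sapiens) for cytotoxicity, read by MTT assay; a higher number here means that more compound is tolerated, a lower number that less compound is tolerated:
Compound 1 `O=C(CSc1nnnn1-c1cccc2ccccc12)N/N=C/c1cccs1` gives > 316000 nM, which is a limit of the assay.
Compound 2 `COc1ccc(/C=N/NC(=O)CSc2nnnn2-c2cccc3ccccc23)cc1` gives > 298000 nM, also a limit of the assay.
Among the measured compounds shown here, compound 3 `COc1ccc(/C=N/NC(=O)CSc2nnnn2-c2cccc3ccccc23)cc1OC` gives 191000 nM, the only number among the three.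

For the measured compounds named here, compound 3 thus stands alone as the one compound with a number in this assay; the other two sit at limits, so no ordering beyond the scatter can be read. The steps of an at least 1.6-fold lower number from compound 1 to compound 3 (0.21 log units; that floor lies within the scatter) and an at least 1.5-fold lower number from compound 2 to compound 3 (0.19 log units; that floor lies within the scatter) set only floors that lie within the scatter, and the step that the two limits leave unreadable from compound 1 to compound 2 cannot be read at all. Compound 4 `COc1cc(/C=N/NC(=O)CSc2nnnn2-c2cccc3ccccc23)ccc1O` differs from compound 3 by hydrogen in place of methyl on an oxygen on an aromatic ring. Going by the values given here, no measured step alters a group on an oxygen, so none bears directly on it, and no change beyond the scatter is expected. Compound 4 is therefore estimated at 220000 nM, between 100000 nM and 400000 nM, an expected step of a 1.2-fold higher number from compound 3 to compound 4 (0.06 log units; within the scatter).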

Compound 4, half-maximal cytotoxic concentration: > 287000 nM
Compound 4: a limit, no number; the forecaster's own chance of this, stated with the estimate: 35%; middle value at least 1.3-fold (0.11 log units) from the limit.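

In this assay, compound 4 gives a limit of the assay, not a number: the limit of > 287000 nM in this assay, at which 1 of the 4 values shown sits.

Among the compounds shown here, no earlier step altered a group on an oxygen; here, hydrogen in place of methyl gives an at least 1.5-fold higher number from compound 3 to compound 4 (0.17 log units; that floor lies within the scatter), so this change has only a floor, and it does not go beyond the scatter. The steps joining compound 4 to compound 1 and compound 2 run from limit to limit and cannot be read.

As far as these compounds go, the true size of this step remains open. So does what an ethyl group or a longer chain on that oxygen, or an amine in place of the hydroxy, would do to the number.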